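A few compounds are considered here, and "the series" means these few. Any claim that something is new, unique, unknown or untested is made for them only; others in the source may bear on it.

In an assay on isolated protein for inhibition of DNA topoisomerase 1 (Homo sapiens), with a stated time of 30 min, tested at 100 uM (a higher number here means more inhibition at the concentration tested (going by the name of the read-out), a lower number less inhibition), three close relatives of one shared core have been measured. Compound 1 `Oc1ccc(-c2cc(-c3cccc(O)c3)nc(-c3ccccc3O)c2)cc1` gives 1.5%. Compound 2 `Oc1cccc(-c2cc(-c3ccccc3O)cc(-c3ccccc3O)n2)c1` carries a 2-hydroxyphenyl where compound 1 carries a 4-hydroxyphenyl; in this assay compound 2 gives 0%. Compound 3 `Oc1ccc(-c2cc(-c3cccc(O)c3)cc(-c3cccc(O)c3)n2)cc1` gives 0%. Within the data shown here, none of the three shows any appreciable inhibition, and the only step between single-point neighbours, a number 1.5 percentage points lower from compound 1 to compound 2 (within the scatter), stays within the scatter of the measurement. Compound 3 therefore stands level with compound 2 at the digits reported, the two of them together at the bottom of the three numbers, with compound 1 a hair higher but still indistinguishable from them within the scatter.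

Compound 4 `Oc1cccc(-c2cc(-c3cccc(O)c3)nc(-c3ccccc3O)c2)c1` is the next member to be tested. It differs from compound 3 in one place: 2-hydroxyphenyl in place of 4-hydroxyphenyl on an aromatic carbon. The same exchange of a 4-hydroxyphenyl for a 2-hydroxyphenyl has already been seen once, from compound 1 to compound 2, and there it produced a number 1.5 percentage points lower from compound 1 to compound 2 (within the scatter), a shift no larger than the usual noise. Among the measured compounds shown here, with that single precedent as the only guide, no step beyond the scatter is expected here either, and the estimated move is a number 1 percentage points higher from compound 3 to compound 4 (within the scatter). For compound 4 the expected result in this assay is thus 1%, with a range from -5% to 8%.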

Compound 4, a percentage reported as inhibition, at one concentration (the size of the read-out at that concentration, not a potency): 1.9%
Beside the measured number, compound 4's estimate is 0.9 percentage points below it, within the range that was stated.
By their numbers in this assay, from the lowest: compounds 2, 3, 1 and 4 (each within the scatter of the next).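

The exchange of a 4-hydroxyphenyl for a 2-hydroxyphenyl, on an aromatic carbon next to the ring nitrogen, now has a second example, and in this assay it again gives a step that cannot be told from noise, namely a number 1.9 percentage points higher from compound 3 to compound 4 (within the scatter). The two exchanges that bring in a 3-hydroxyphenyl at a single place behave the same way, with a number 1.9 percentage points higher from compound 2 to compound 4 (within the scatter) and a number 0.4 percentage points higher from compound 1 to compound 4 (within the scatter), so among these four compounds all three hydroxyphenyl groups have been exchanged at this position without a step beyond the scatter. The two examples of the same change also agree with each other as far as the measurement can tell: the same change on two cores in this assay, a number 1.5 percentage points lower (within the scatter) from compound 1 to compound 2 and a number 1.9 percentage points higher (within the scatter) from compound 3 to compound 4, 3.4 percentage points apart, within the scatter of two such steps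

Among these compounds, all four compounds show very little inhibition at the one concentration tested, so no step here points to any part of the structure that matters for inhibition. From the compounds shown here alone, it remains open whether a group of a different kind at this position, such as an amine, a carboxylic acid or a methoxy group in place of the hydroxyl, would move the number beyond the scatter at all.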